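Swapping the Amide Nitrogen Group on a Shared Core

A few compounds are considered here, and "the series" means these few. Any claim that something is new, unique, unknown or untested is made for them only; others in the source may bear on it.

Compound 1 `COc1cc2c(cc1OC)C(CC(N)=O)CC2` was tested in a functional assay on the whole organism (strain Wistar) for inhibition, with Rattus norvegicus as the target, read by paw edema, with stated times of 60 min and 2 h, at a dose of 100 mg/kg by the oral route (on this read-out higher numbers stand for more inhibition at the one dose given (going by the name of the read-out) and lower numbers for less inhibition), where compound 1 gives 31%. Among the compounds with values here, only one other compound has been measured: compound 2 `CCNC(=O)CC1CCc2cc(OC)c(OC)cc21`, which in this assay gives 26%. Compound 1 thus stands at the top of the two numbers, but the step of a number 5 percentage points lower from compound 1 to compound 2 (within the scatter) means the two compounds cannot be told apart.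

Compound 3 `COc1cc2c(cc1OC)C(CC(=O)N1CCOCC1)CC2` differs from compound 1 at the same amide: morpholin-4-yl in place of amino on a carbonyl carbon. Within the data shown here, the one measured step that bears on this change is a number 5 percentage points lower from compound 1 to compound 2 (within the scatter), also a change of what sits on the amide nitrogen, and it stayed within the scatter. Replacing the amide nitrogen's hydrogens with a ring is a larger change than adding ethyl, so a somewhat lower number is expected, but no step beyond the scatter is anticipated: a number 7 percentage points lower from compound 1 to compound 3 (within the scatter). Compound 3 is therefore estimated at 24%, in a range from 8% to 40%.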

Compound 3, a percentage reported as inhibition, in the whole organism at one dose (the size of the read-out at that dose, not a potency): 14%
Compound 3: middle estimate off by 10 percentage points, on the high side, and the stated range covers the measured number.
By their numbers in this assay, from the lowest: compound 3; then compounds 2 and 1 (each within the scatter of the next).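

In this assay, within the data shown here, morpholin-4-yl on the carbonyl carbon brings the first change at this position that stands clear of the scatter, with a number 17 percentage points lower from compound 1 to compound 3 (beyond the scatter) and with a number 12 percentage points lower from compound 2 to compound 3 (beyond the scatter) as well. What sits on this carbonyl carbon can therefore matter for the inhibition seen here, which the step to the ethyl amide alone could not show. Nothing available explains why the number falls with this group.

The change brings in a ring and an oxygen and removes the amide hydrogen all at once, so the compounds shown cannot say which of these features goes with the lower number. A piperidin-1-yl amide, which has a ring without the oxygen, and a diethylamino amide, which has no ring, would help to separate them.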